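The source may hold more compounds than are shown below. What is called first, only, known or untested is meant among the compounds shown, and "the series" means these compounds.

In a functional assay on K562 cells (Homo sapiens) for antiproliferative activity, with a stated time of 72 h (a higher number here means a weaker inhibitor, a lower number a stronger inhibitor), compound 1 (`OC[C@H]1O[C@@H](n2cnc3c(NCc4ccc(Cl)cc4)ncnc32)[C@H](O)[C@@H]1O`) reads 218000 nM while compound 2 (`OC[C@H]1O[C@@H](n2cnc3c(NCc4cccc(Br)c4)ncnc32)[C@H](O)[C@@H]1O`) reads 19700 nM and compound 3 (`OC[C@H]1O[C@@H](n2cnc3c(NCc4ccc(Br)cc4)ncnc32)[C@H](O)[C@@H]1O`) reads 68200 nM as the middle value of the three. Compound 4 (`Cc1cccc(CNc2ncnc3c2ncn3[C@@H]2O[C@H](CO)[C@@H](O)[C@H]2O)c1`) differs from compound 3 by one change (3-methylphenyl in place of 4-bromophenyl on a saturated chain carbon bound to a nitrogen on an aromatic ring), with 3-methylphenyl in place of 4-bromophenyl. The closest guide is the modest step (a 3.5-fold higher number from compound 2 to compound 3 (0.54 log units; beyond the scatter)) from 3-bromophenyl to 4-bromophenyl. The large step (an 11-fold lower number from compound 1 to compound 2 (1.04 log units; beyond the scatter)) and the modest step (a 3.2-fold lower number from compound 1 to compound 3 (0.50 log units; beyond the scatter)) show that swaps in this group can move the number beyond the scatter. For the measured compounds named here, no measured compound carries a methyl, so only a modest step to a lower number is expected in this assay here. Compound 4 is estimated at 30000 nM within an expected range of 9000 nM to 100000 nM once measured. That estimate means an expected 2.3-fold lower number from compound 3 to compound 4 (0.36 log units; beyond the scatter) overall.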

Compound 4, half-maximal inhibitory concentration: > 166000 nM
Compound 4: only a limit was reported (the forecaster's own chance of this, stated with the estimate: 10%); middle value at least 5.5-fold (0.74 log units) from the limit.
By their numbers in this assay, from the lowest: compound 2; then compound 3; then compound 1.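

Compound 4 gives no number, only a limit of the assay: the limit of > 166000 nM in this assay, at which 1 of the 4 values shown sits.
Even so, the first non-halogen group on this ring moves the reading towards a weaker inhibitor, with an at least 2.4-fold higher number from compound 3 to compound 4 (0.38 log units; beyond the scatter) for 3-methylphenyl in place of 4-bromophenyl and an at least 8.4-fold higher number from compound 2 to compound 4 (0.92 log units; beyond the scatter) for methyl in place of bromo on an aromatic carbon, so swapping the bromo of compound 2 for methyl gives no gain here. The step from compound 1 to compound 4 cannot be read.

As far as these compounds go, how far past its limit compound 4 lies stays open. Also open, from the compounds shown here alone, is whether a methoxy group or an amine on this ring would hold the reading of compound 2.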